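The compounds below may be only part of what the source reports. "The series", "measured", "known", "first", "only" and "open" are said of these compounds alone.

Within the data shown here, compound 1 `Clc1ccc2oc(SCCCN3CCCC3)nc2c1` is one of two compounds measured in an ADME assay on microsomes from liver (Mus musculus) for metabolic stability, read by LC-MS, using NADPH, with a stated time of 45 min, tested at 0.5 uM; on this read-out higher numbers stand for fast clearance and lower numbers for slow clearance. In this assay compound 1 gives 10.4 mL/min/g, the lowest of the two numbers; its neighbour, compound 2 `O=C1CCCN1CCCSc1nc2cc(Cl)ccc2o1`, gives 51 mL/min/g. Among the measured compounds shown here, the one measured step, 2-oxopyrrolidin-1-yl in place of pyrrolidin-1-yl on a saturated chain carbon three bonds along the chain from a sulfur, is a 4.9-fold higher number from compound 1 to compound 2 (0.69 log units; beyond the scatter).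

Compound 3 `CN(C)C(=O)CCSc1nc2cc(Cl)ccc2o1` is not yet measured. It differs from compound 1 thus: dimethylcarbamoyl in place of (pyrrolidin-1-yl)methyl on a saturated chain carbon, two bonds along the chain from a sulfur. As in the measured step, a basic nitrogen leaves and a carbonyl enters on the chain, so a higher number is expected for compound 3 in this assay, of a size near that seen from compound 1 to compound 2. The expected step is a 3.4-fold higher number from compound 1 to compound 3 (0.53 log units; beyond the scatter). Compound 3 is therefore estimated at 35 mL/min/g, within a range from 12 mL/min/g to 90 mL/min/g.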

Compound 3, intrinsic clearance in a liver preparation (reported as CLH), per the amount of preparation that the assay uses: 41.8 mL/min/g
Compound 3: middle estimate off by 1.2-fold (0.08 log units), on the low side, within the range that was stated.
By their numbers in this assay, from the lowest: compound 1; then compounds 3 and 2 (each within the scatter of the next).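

Replacing the ring-bearing (pyrrolidin-1-yl)methyl with dimethylcarbamoyl, on a saturated chain carbon two bonds along the chain from a sulfur, gives a 4.0-fold higher number from compound 1 to compound 3 (0.60 log units; beyond the scatter) in this assay. The earlier step placed a carbonyl inside a five-membered ring; here the carbonyl sits in a group with no ring, and the number still rises beyond the scatter, so among these compounds a higher number does not require that ring. Nothing shown here gives a reason for this rise.

The compounds shown leave open whether the rise follows the loss of the pyrrolidin-1-yl group or the arrival of the carbonyl, as the two changes come together in both steps. A chain ending in dimethylamino, an amine with no carbonyl and no ring, could begin to pull these two changes apart.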